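Ethynyl in Place of Thiophen-3-yl on a Shared Core

The compounds below may be only part of what the source reports. "The series", "measured", "known", "first", "only" and "open" are said of these compounds alone.

Compound 1 `C#Cc1cn([C@@H]2O[C@H](CO)[C@@H](O)[C@H]2O)c2ncnc(C)c12`: 290 nM
Compound 2 `CSc1ncnc2c1c(-c1ccsc1)cn2[C@@H]1O[C@H](CO)[C@@H](O)[C@H]1O`: > 15000 nM

Of the compounds shown here, two have been measured in a functional assay on HepG2 cells (Homo sapiens) for antiproliferative activity, read by XTT assay, with a stated time of 72 h; a higher number here means a weaker inhibitor, a lower number a stronger inhibitor. Compound 1 `C#Cc1cn([C@@H]2O[C@H](CO)[C@@H](O)[C@H]2O)c2ncnc(C)c12` gives 290 nM in this assay. Compound 2 `CSc1ncnc2c1c(-c1ccsc1)cn2[C@@H]1O[C@H](CO)[C@@H](O)[C@H]1O` reaches only a limit of the assay, > 15000 nM, in this assay; it sits at the boundary described by the limit of > 15000 nM in this assay, at which 1 of the 2 values shown sits, so no number is known for it, only that it is a weak inhibitor at best.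

Compound 3 `C#Cc1cn([C@@H]2O[C@H](CO)[C@@H](O)[C@H]2O)c2ncnc(SC)c12` has not yet been measured. It differs from compound 2 in one place: ethynyl in place of thiophen-3-yl on an aromatic carbon. The same ethynyl group is present in compound 1, which carries a methyl rather than a methylthio group elsewhere on the shared core, and compound 1 is the stronger of the two measured compounds.

Within the data shown here, since no measured pair differing in a single place is available, the expected size of the step in this assay rests on these two values alone. The step of an at least 12-fold lower number from compound 2 to compound 3 (1.09 log units; beyond the scatter) is expected to run toward stronger inhibition, by more than the usual scatter. Compound 3 is therefore estimated at 1200 nM, within a range of 200 nM to 8000 nM.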

Compound 3, half-maximal inhibitory concentration: > 15000 nM
Compound 3 gave a limit, no number; the forecaster's own chance of this, stated with the estimate: 15%; at least 12-fold (1.09 log units) between middle value and limit.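

In this assay, ethynyl on this aromatic carbon does not by itself give measurable inhibition, since the other group on the shared core also counts: methylsulfanyl in place of methyl on an aromatic carbon brings an at least 51-fold higher number from compound 1 to compound 3 (1.71 log units; beyond the scatter). The earlier compounds shown here could not show this, as the ethynyl group had been measured only with methyl on the core and the methylsulfanyl group only with thiophen-3-yl. Compound 2 and compound 3 both stand at a limit of the assay rather than at a number, so the step from thiophen-3-yl to ethynyl cannot be read and neither group can be ranked over the other on the methylsulfanyl core: the limit of > 15000 nM in this assay, at which 2 of the 3 values shown sit.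

The compounds shown leave open whether an amine or a methoxy group in place of methylsulfanyl would bring a value closer to that of compound 1, at 290 nM. They also leave open whether thiophen-3-yl on this aromatic carbon would give a readable value with methyl on the core, and whether a longer chain such as propynyl would be tolerated there in place of ethynyl.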